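Swapping the Ether Cap: From Compound 3 to Compound 4

This account rests on a few compounds, and the source may have more. Where it says the series, first, only, none or still open, it means among the compounds named here.

Of the compounds shown here, three have been tested, or at least entered, in an assay on HEK293T cells for inhibition of nuclear factor NF-kappa-B complex (Homo sapiens), read by a luciferase reporter, with stated times of 6 h and 8 h; a higher number here means a weaker inhibitor, a lower number a stronger inhibitor. Compound 1 `CN(c1ccc(Oc2ncnc3sccc23)cc1)c1nccc(N2CCc3ccccc3C2)n1` was not determined there: in this assay compound 1 gives "not determined" (no result reported). Compound 3 `c1ccc2c(c1)CCN(c1ccnc(Nc3ccc(Oc4ncnc5sccc45)cc3)n1)C2` is in the same position: in this assay compound 3 gives "not determined" (no result reported). So no number stands for either of them. Compound 2 `CNC(=O)c1cc(Oc2ccc(Nc3nccc(N4CCCC4)n3)cc2)ccn1` is the only one with a result: in this assay compound 2 gives 3720 nM.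

Compound 3 therefore has no position on the numbers shown; it is one of two entries without a single value, and nothing measured connects it to compound 2.

Compound 4 `CNC(=O)c1cc(Oc2ccc(Nc3nccc(N4CCc5ccccc5C4)n3)cc2)ccn1` is compound 3 with one part exchanged, (a group of 10 heavy atoms (7 carbon, 2 nitrogen, 1 oxygen; one six-membered aromatic ring with 1 hetero atom) in place of a group of 9 heavy atoms (6 carbon, 2 nitrogen, 1 sulfur; one five-membered aromatic ring with 1 hetero atom, one six-membered aromatic ring with 2 hetero atoms), on an oxygen on an aromatic ring). For the measured compounds named here, no step between two measured compounds is available to say how such an exchange shifts this assay, in either direction. Going by the values given here, the only anchor is compound 2, which carries the same entering group on the same oxygen but differs elsewhere, so its value of 3720 nM can guide the scale only loosely.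

On that basis compound 4 is expected to land near 2500 nM, with a range from 500 nM to 12000 nM, and the direction of any difference from compound 3 cannot be stated, since compound 3 has no number.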

Compound 4, half-maximal inhibitory concentration: 7780 nM
Estimate against measurement, compound 4: 3.1-fold (0.49 log units) below; measured number inside the range.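

For the compounds shown here, compound 4 supplies the first step between two measured compounds in this assay: putting 1,2,3,4-tetrahydroisoquinolin-2-yl in place of pyrrolidin-1-yl on an aromatic carbon gives a 2.1-fold higher number from compound 2 to compound 4 (0.32 log units; beyond the scatter) and so a modest weakening that lies beyond the usual scatter. This shows that, with 2-(methylcarbamoyl)pyridin-4-yl on the oxygen, the read-out responds to the group on that aromatic carbon, although the exchange on the oxygen itself, from compound 3 to compound 4, cannot be read while compound 3 has no number. Nothing among the available data accounts for the shift.

Going by these compounds alone, with only two values for this aromatic carbon, one step cannot show a trend, and it remains open what a piperidin-1-yl or morpholin-4-yl group there would give. On these data alone, it is also open how the result would change if a carboxylic acid took the place of the methylcarbamoyl group on the pyridine ring, or if a longer chain replaced the methyl on that amide.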